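The source may report more compounds than this note shows. Statements on the series, on what has been measured and on what is new or still open speak of the compounds shown alone.

Working notes on the series in an ADME assay on HS27 cells (Homo sapiens) for cytotoxicity, read by MTT assay, with a stated time of 24 h; on this read-out higher numbers stand for weaker inhibition of growth and lower numbers for stronger inhibition of growth.

Three compounds are measured. Compound 1 `Cc1ccc(NC(=O)Nc2ccccc2F)cc1NC(=O)c1cnoc1C` gives only a limit of the assay, > 30000 nM. Compound 2 `Cc1ccc(NC(=O)Nc2cccc(Cl)c2)cc1NC(=O)c1cnoc1C` likewise gives only a limit, > 30000 nM. Compound 3 `Cc1cc(NC(=O)Nc2cccc(Cl)c2)ccc1NC(=O)c1cnoc1C` also returns a limit, > 30000 nM. Among the compounds with values here, all three sit at the limit of > 30000 nM in this assay, at which 3 of the 3 values shown sit, so no step is readable among them.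

The change from compound 2 to compound 1 is 2-fluorophenyl in place of 3-chlorophenyl on an amide-type nitrogen, and the step it made, a step that the two limits leave unreadable from compound 2 to compound 1, is not readable from two limits. The difference between the cores of compound 3 and compound 2 is not broken down here.

Compound 4 `Cc1cc(NC(=O)Nc2ccccc2F)ccc1NC(=O)c1cnoc1C` is not yet measured. It carries the same change, (2-fluorophenyl in place of 3-chlorophenyl on an amide-type nitrogen), on the core of compound 3. Because compound 3 gives > 30000 nM and the step in compound 1 was unreadable, the expected step that the limit leaves unreadable from compound 3 to compound 4 is near nil, with another limit the most likely outcome. Compound 4 is estimated at 40000 nM, within 20000 nM to 100000 nM.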

Compound 4, concentration for 50% growth inhibition: > 30000 nM
Compound 4 was reported as a limit; the forecaster's own chance of this, stated with the estimate: 85%; the middle value does not contradict the limit.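

Compound 3 and compound 4 both return only a limit in this assay, so no new step can be read between them: the limit of > 30000 nM in this assay, at which 4 of the 4 values shown sit.

The compounds shown leave open whether 2-fluorophenyl and 3-chlorophenyl differ on either core, and at what concentration, if any, growth inhibition appears.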